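A Methanesulfonamido Group on the Distal Ring

This account rests on a few compounds, and the source may have more. Where it says the series, first, only, none or still open, it means among the compounds named here.

Compound 1 `O=C(O)CC/C=C\CO[C@H]1[C@@H](OCc2ccc(-c3ccccc3)cc2)CC[C@@H]1N1CCCCC1` gives 10 nM; 7.94 nM (2 entries) in a functional assay on blood for antagonist activity at thromboxane A2 receptor (Homo sapiens); on this read-out lower numbers stand for tighter binding and higher numbers for weaker binding.
Compound 2 `O=C(O)CC/C=C\CO[C@H]1C(OCc2ccc(-c3ccccc3)cc2)CC[C@@H]1N1CCCCCC1` gives 12.6 nM in this assay.
Compound 3 `O=C(O)CC/C=C\CO[C@@H]1[C@@H](OCc2ccc(-c3ccccc3)cc2)CC[C@@H]1N1CCCCC1` gives 100 nM in this assay.

Compound 2 holds the lowest of the two single numbers in this assay; its nearest neighbour is compound 3, whose number is higher by a margin beyond the scatter. Compound 1 has two entries rather than one number (the several entries of compound 1 in this assay, 10 nM; 7.94 nM (2 entries)). Compounds 1 and 3 differ only in configuration (the fact that compounds 1 and 3 differ only in the configuration as drawn), and their values show a clear gap.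

Compound 4 `CS(=O)(=O)Nc1cccc(-c2ccc(COC3CC[C@H](N4CCCCCC4)[C@H]3OC/C=C\CCC(=O)O)cc2)c1` differs from compound 2 by methanesulfonamido in place of hydrogen on an aromatic carbon, meta to a large group. For the measured compounds named here, no measured pair shows a change of this kind, so the size of the step cannot be read from the present numbers. The step of a 1.6-fold lower number from compound 2 to compound 4 (0.20 log units; within the scatter) is expected to be small, within or barely beyond the scatter, in either direction. Compound 4 is therefore estimated at 8 nM, with a range from 2.5 nM to 25 nM.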

Compound 4, dissociation constant: 12.6 nM
Beside the measured number, compound 4's estimate is 1.6-fold (0.20 log units) below it; the measured number falls inside the stated range.
By their numbers in this assay, from the lowest: compounds 2 and 4 (each within the scatter of the next); then compound 3.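

In this assay, the change from phenyl to 3-(methanesulfonamido)phenyl gives no change at the digits printed from compound 2 to compound 4 (within the scatter) and so shows that this aromatic carbon, meta to a large group, accepts methanesulfonamido, with its hydrogen-bond donor and acceptors, without a change beyond the scatter. The earlier compounds shown here all carry plain phenyl at this place, so they said nothing about substitution on this ring. This holds for this one pair only.

As far as these compounds go, whether the same carbon would accept a carboxylic acid or an acetamido group, and whether methanesulfonamido would read the same at another carbon of this ring or on the core of compound 1, remains open. Nothing measured in this set bears on why this step is as small as it is.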